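Methoxypyridine to carboxypyridine: an expected solubility step

The source may report more compounds than this note shows. Statements on the series, on what has been measured and on what is new or still open speak of the compounds shown alone.

Measured compounds:
Compound 1, `COc1ccc(Nc2cc3[nH]c(-c4cccc(C(F)(F)F)c4)nc3cn2)nc1`. In a physicochemical assay for solubility, using the shake flask method, measured as kinetic solubility, with a stated time of 20 h, at pH 2 (a lower number here means a less soluble compound, a higher number a more soluble compound), compound 1 gives < 5000 nM, which is a limit of the assay rather than a number.
Compound 2, `Fc1ccc(-c2nc3cnc(Nc4cc(C(F)(F)F)ccn4)cc3[nH]2)cc1F`. In this assay compound 2 gives < 5000 nM, again a limit rather than a number.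
Compound 3, `Fc1ccc(Nc2cc3[nH]c(-c4ccc(F)c(C(F)(F)F)c4)nc3cn2)nc1`. In this assay compound 3 gives 13000 nM.

Among the measured compounds shown here, compound 1 therefore stands only at a limit in this assay, and the same holds for compound 2; compound 3 is the only compound here with a number. This is summed up by the limit of < 5000 nM in this assay, at which 2 of the 3 values shown sit. For the measured compounds named here, no two of the measured compounds differ in just one place, so no measured step can be followed, and the three values give no direction for what a single change does.

Compound 4, `O=C(O)c1ccnc(Nc2cc3[nH]c(-c4cccc(C(F)(F)F)c4)nc3cn2)c1`, has not yet been measured in this assay. It differs from compound 1 by 4-carboxypyridin-2-yl in place of 5-methoxypyridin-2-yl on a nitrogen on an aromatic ring. Because compound 1 sits at < 5000 nM, a limit, the step of an at least 2.4-fold higher number from compound 1 to compound 4 (0.38 log units; beyond the scatter) is an expectation that can only be anchored loosely, and it is expected to go upward, beyond the usual scatter. Compound 4 is expected to give about 12000 nM in this assay, within a range from 3500 nM to 45000 nM.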

Compound 4, solubility: < 5000 nM
Compound 4: only a limit was reported; the forecaster's own chance of this, stated with the estimate: 35%; middle value at least 2.4-fold (0.38 log units) from the limit.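

In this assay compound 4 gives < 5000 nM, a limit and not a number. Among the compounds shown here, compound 1 also stands at a limit, so no step from compound 1 to compound 4 can be read. The compounds shown leave open whether 4-carboxypyridin-2-yl in place of 5-methoxypyridin-2-yl changes the read-out at all, and most values stop at the same point: the limit of < 5000 nM in this assay, at which 3 of the 4 values shown sit.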